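From Methoxy to Dimethylamino on the Way to Compound 4

The compounds below may be only part of what the source reports. "The series", "measured", "known", "first", "only" and "open" are said of these compounds alone.

Of the compounds shown here, three have been tested so far in a functional assay on P388 cells (Mus musculus) for inhibition; a lower number here means a stronger inhibitor, a higher number a weaker inhibitor. Among the measured compounds shown here, compound 1 (`COc1cc2ccc(CCc3ccc4ccccc4c3)cc2cc1O`) gives 3590 nM, the only true number available. Compound 2 (`COc1ccc(/C=C\c2ccc3ccccc3c2)cc1[N+](=O)[O-]`) reads > 20000 nM, which is a limit of the assay and not a number. Compound 3 (`COc1c([N+](=O)[O-])cc(/C=C\c2ccc3ccccc3c2)cc1[N+](=O)[O-]`) reads > 5000 nM, and this too is only a limit. Compound 3 therefore has no exact place on the scale, and any comparison with it stays loose.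

Compound 4 (`CN(C)c1c([N+](=O)[O-])cc(/C=C\c2ccc3ccccc3c2)cc1[N+](=O)[O-]`) keeps everything in compound 3 except one group: dimethylamino in place of methoxy on an aromatic carbon. In words, dimethylamino takes the place of methoxy on an aromatic carbon, ortho to two nitro groups. For the measured compounds named here, the one measured step close to this change is a step that the two limits leave unreadable from compound 2 to compound 3. That step puts nitro in place of hydrogen, leaves the methoxy untouched and has no readable size, so it offers no size to carry over. Going by the values given here, no measured pair shows the swap itself. With nothing to suggest a shift in either direction, no change beyond the scatter is expected in this assay.

The estimated step is a step that the limit leaves unreadable from compound 3 to compound 4. For compound 4 the expected value is 7000 nM, with an estimated range from 2000 nM to 25000 nM.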

Compound 4, half-maximal inhibitory concentration: > 5000 nM
Compound 4 ended at the assay's limit (the forecaster's own chance of this, stated with the estimate: 50%); the middle value does not contradict the limit.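

In this assay, compound 3 and compound 4 both read as a limit of the assay and not as a number, and no step can be read between them. The compounds shown leave open whether putting dimethylamino in place of methoxy changes inhibition at all, and if it does, in which direction and by how much.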